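The source may report more compounds than this note shows. Statements on the series, on what has been measured and on what is new or still open speak of the compounds shown alone.

- compound 1 `COc1ccc(/C=C/C(=O)c2c(OC)cc(O)c(CC=C(C)C)c2O)cc1`: 32400 nM
- compound 2 `COc1ccc(/C=C/C(=O)c2c(OC)cc(O)c(CC=C(C)C)c2O)cc1OC`: 13800 nM

Among the measured compounds shown here, in a functional assay on HepG2 cells (Homo sapiens) for inhibition, read by MTT assay, with a stated time of 72 h (a lower number here means a stronger inhibitor, a higher number a weaker inhibitor), compound 1 gives 32400 nM, the higher of the two numbers measured so far. Compound 3 `COc1cc(O)c(CC=C(C)C)c(O)c1C(=O)/C=C/c1ccc(C(F)(F)F)cc1` departs from the core of compound 1 at one place: trifluoromethyl in place of methoxy on an aromatic carbon. This puts trifluoromethyl in place of methoxy on an aromatic carbon, para to a large group.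

For the measured compounds named here, only one measured step bears on this change: a 2.3-fold lower number from compound 1 to compound 2 (0.37 log units; beyond the scatter), a modest one, for methoxy in place of hydrogen on an aromatic carbon. Going by the values given here, no measured pair exchanges methoxy for trifluoromethyl, so the direction rests on thin evidence. A small move towards a lower number in this assay is expected, no larger than that modest step and possibly within the scatter. The expected step is a 1.6-fold lower number from compound 1 to compound 3 (0.21 log units; within the scatter). Compound 3 is estimated at 20000 nM, with an expected range of 8000 nM to 45000 nM.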

Compound 3, half-maximal inhibitory concentration: 6500 nM
Estimate against measurement, compound 3: 3.1-fold (0.49 log units) above; the measured number lies below the stated range.
By their numbers in this assay, from the lowest: compound 3; then compound 2; then compound 1.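

Replacing the methoxy on the aromatic carbon para to a large group with trifluoromethyl gives a 5.0-fold lower number from compound 1 to compound 3 (0.70 log units; beyond the scatter) in this assay, so this methoxy is not needed for the activity seen in the series. The earlier step, a 2.3-fold lower number from compound 1 to compound 2 (0.37 log units; beyond the scatter), kept this methoxy and added a second one, whereas this change removes it and the number still falls, with 0 hydrogen-bond acceptors in the entering group against 1 in the group that leaves. No measurement here accounts for the lower number.

Going by these compounds, it remains open whether the fall follows from trifluoromethyl itself or simply from the loss of methoxy, a question that a plain hydrogen, a chlorine or an amine on the same carbon would help to settle. Also open, on these data alone, is whether a nitrile or a carboxylic acid there would continue the trend or reverse it.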